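Notes on the step from compound 1 to compound 3

The source may report more compounds than this note shows. Statements on the series, on what has been measured and on what is new or still open speak of the compounds shown alone.

Within the data shown here, in a functional assay on MDA-MB-231 cells (Homo sapiens) for cytotoxicity, read by MTT assay, with a stated time of 72 h (a higher number here means a weaker inhibitor, a lower number a stronger inhibitor), compound 1 `CC1(C)OCC(Cn2cc(Cn3c4c(c5ccccc53)C(=O)c3c[n+]([O-])c5ccccc5c3C4=O)nn2)O1` gives 230 nM as the lower of the two numbers so far. Compound 2 `O=C1c2c[n+]([O-])c3ccccc3c2C(=O)c2c1c1ccccc1n2CCN1CCCC1` gives 630 nM and so stands higher, beyond the usual scatter. Compound 3 `O=C1c2c[n+]([O-])c3ccccc3c2C(=O)c2c1c1ccccc1n2Cc1cn([C@H]2C[C@H](O)[C@@H](CO)O2)nn1` differs from compound 1 by 4-hydroxy-5-(hydroxymethyl)oxolan-2-yl in place of (2,2-dimethyl-1,3-dioxolan-4-yl)methyl on an aromatic nitrogen with 4-hydroxy-5-(hydroxymethyl)oxolan-2-yl in place of (2,2-dimethyl-1,3-dioxolan-4-yl)methyl on an aromatic nitrogen. Among the measured compounds shown here, no measured pair shows this change. A small step towards a higher number is expected in this assay as a 1.7-fold higher number from compound 1 to compound 3 (0.24 log units; within the scatter) and it may not clear the scatter. Compound 3 is estimated at 400 nM (expected range 150 nM to 1100 nM).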

Compound 3, half-maximal inhibitory concentration: 580 nM
Compound 3: middle estimate off by 1.5-fold (0.16 log units), on the low side; the range from low to high includes it.
By their numbers in this assay, from the lowest: compound 1; then compounds 3 and 2 (each within the scatter of the next).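

In this assay, among these compounds, 4-hydroxy-5-(hydroxymethyl)oxolan-2-yl in place of (2,2-dimethyl-1,3-dioxolan-4-yl)methyl on an aromatic nitrogen gives a 2.5-fold higher number from compound 1 to compound 3 (0.40 log units; beyond the scatter), the first one-place step, so a change at this position can move the number beyond the scatter. The entering group has 2 hydrogen-bond donors against 0 and a ring with 1 hetero atom against 2, and this single step cannot separate those differences. Nothing available explains the step.

Open, on these data alone, is how a carboxylic acid or a primary amine would read at this position. Also open, as far as these compounds go, is whether an open-chain diol would track compound 1 or compound 3.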